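A few compounds are considered here, and "the series" means these few. Any claim that something is new, unique, unknown or untested is made for them only; others in the source may bear on it.

Measured so far in an assay on isolated protein for inhibition of protein deacetylase HDAC6 (Homo sapiens), read by mobility shift assay; a lower number here means a stronger inhibitor, a higher number a weaker inhibitor:
- compound 1, `O=C(NO)c1ccc(CN(Cc2ccc(F)cc2)S(=O)(=O)c2c(F)c(F)c(F)c(F)c2F)cc1`: 13 nM
- compound 2, `O=C(NO)c1ccc(CN(Cc2ccc(C(F)(F)F)cc2)S(=O)(=O)c2c(F)c(F)c(F)c(F)c2F)cc1`: 45 nM

Compound 2 stands highest of the two numbers in this assay; its nearest neighbour is compound 1, reached by the step of a 3.5-fold higher number from compound 1 to compound 2 (0.54 log units; beyond the scatter). Compound 3, `CN(C)c1ccc(CN(Cc2ccc(C(=O)NO)cc2)S(=O)(=O)c2c(F)c(F)c(F)c(F)c2F)cc1`, has not been measured in this assay. Against compound 2 it carries dimethylamino in place of trifluoromethyl on an aromatic carbon. Among the compounds with values here, only one measured step bears on the same aromatic carbon, from compound 1 to compound 2, and it showed a modest weakening on enlarging the substituent there; no measured pair exchanges a substituent for a dimethylamino group, so the direction of the step to compound 3 is not fixed by the data. Given that the one step in this series stayed modest, compound 3 is expected to remain within a modest distance of compound 2, with the step of a 1.3-fold lower number from compound 2 to compound 3 (0.11 log units; within the scatter) as the estimate. Compound 3 is therefore estimated at 35 nM, range 12 nM to 100 nM.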

Compound 3, half-maximal inhibitory concentration: 29 nM
Compound 3: the middle estimate sits 1.2-fold (0.08 log units) above what was measured; low and high end bracket the measured number.
By their numbers in this assay, from the lowest: compound 1; then compounds 3 and 2 (each within the scatter of the next).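

In this assay the exchange of trifluoromethyl for dimethylamino on this aromatic carbon gives a 1.6-fold lower number from compound 2 to compound 3 (0.19 log units; within the scatter), so these two groups cannot be told apart here, although the entering group carries one hydrogen-bond acceptor and the leaving group none. Fluoro remains the group with the lowest number of the three on this carbon, as dimethylamino also gives a modest step in the same direction as trifluoromethyl: a 2.2-fold higher number from compound 1 to compound 3 (0.35 log units; beyond the scatter). Nothing available accounts for how these three groups rank.

Open, as far as these compounds go, is whether any group on this carbon can give a lower number than compound 1 does, with a plain hydrogen or a methoxy group as the nearest comparisons. Also open, from the compounds shown here alone, is how a primary amine or a carboxylic acid would read here, since the dimethylamino result says nothing about either.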